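The source may report more compounds than this note shows. Statements on the series, on what has been measured and on what is new or still open speak of the compounds shown alone.

Measured so far in a functional assay on A549 cells (Homo sapiens) for antiproliferative activity, read by MTT assay, with a stated time of 24 h; a lower number here means a stronger inhibitor, a higher number a weaker inhibitor:
Compound 1 `C=CCc1cc(-c2cccc([N+](=O)[O-])c2)ccc1O`: > 100000 nM, a limit of the assay.
Compound 2 `C=CCc1cc(-c2ccccc2)ccc1O`: > 100000 nM, a limit of the assay.
Compound 3 `C=CCc1cc(-c2cccc(SC)c2)ccc1O`: 66000 nM.

Compound 2 stands at > 100000 nM, which is a limit and not a number. This is the limit of > 100000 nM in this assay, at which 2 of the 3 values shown sit, so compound 2 has no exact value to start from.

Compound 4 `C=CCc1cc(-c2ccc(C(F)(F)F)cc2)ccc1O` differs from compound 2 by one change, trifluoromethyl in place of hydrogen on an aromatic carbon, para to a large group: trifluoromethyl in place of hydrogen on an aromatic carbon.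

Going by the values given here, two measured steps bear on this change. The closer one is an at least 1.5-fold lower number from compound 2 to compound 3 (0.18 log units; that floor lies within the scatter), in which a different group, methylsulfanyl, replaces hydrogen on an aromatic carbon. The other is a step that the two limits leave unreadable from compound 1 to compound 2, with hydrogen in place of nitro, and it gives no size to work from. Among the compounds with values here, the only guide to size is therefore a step whose floor lies within the scatter, so a modest move toward a lower number is expected in this assay, or none beyond the scatter. Compound 4 could also be reported only as a limit. The expected change is an at least 1.2-fold lower number from compound 2 to compound 4 (0.09 log units; that floor lies within the scatter). The estimated value for compound 4 is 80000 nM, with an expected range from 35000 nM to 150000 nM.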

Compound 4, half-maximal inhibitory concentration: 76000 nM
The estimate for compound 4 lay 1.1-fold (0.02 log units) above the measured number; measured number inside the range.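

In this assay, trifluoromethyl in place of hydrogen on an aromatic carbon, para to a large group, gives an at least 1.3-fold lower number from compound 2 to compound 4 (0.11 log units; that floor lies within the scatter). Compound 4 is the first compound shown with a group at this place, and it shows that a group here, with 4 heavy atoms, no ring, no net charge and 0 hydrogen-bond donors or acceptors, can go with a readable number on the shared core. Only the floor of this step can be read, and its true size stays unknown because compound 2 has no exact value to start from: the limit of > 100000 nM in this assay, at which 2 of the 4 values shown sit.

The compounds shown leave open whether this readable number is particular to trifluoromethyl or would also appear with an amine, a carboxylic acid or a longer chain at the same place, and how far such a group would move the number. Compound 3 and compound 4 differ in more than one place, so these compounds also cannot separate what the choice of group contributes from what its location on the aromatic ring contributes.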